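Swapping an Ester-Bearing Chain for Cyclopentyl on a Tripeptide

The compounds below may be only part of what the source reports. "The series", "measured", "known", "first", "only" and "open" are said of these compounds alone.

Compound 1 `CCCCC(C(=O)OC)N1C(=O)/C(=C/c2ccc(C(=O)N[C@@H](CCCNC(=N)N)C(=O)N[C@@H](CCCCN)C(=O)N[C@@H](CCCC)C(N)=O)cc2)SC1=S`: 0.87 10^-6 cm/s
Compound 2 `CCCC[C@H](NC(=O)[C@H](CCCN)NC(=O)[C@H](CCCNC(=N)N)NC(=O)c1ccc(/C=C2\SC(=O)N(Cc3ccccc3)C2=O)cc1)C(N)=O`: "impermeable" (no number reported)
Compound 3 `CCCC[C@H](NC(=O)[C@H](CCCCN)NC(=O)[C@H](CCCNC(=N)N)NC(=O)c1ccc(/C=C2\SC(=O)N(Cc3ccc(Cl)cc3)C2=O)cc1)C(N)=O`: 1.11 10^-6 cm/s

In an ADME assay for permeability, using PAMPA (on this read-out higher numbers stand for higher permeability and lower numbers for lower permeability), compound 1 gives 0.87 10^-6 cm/s, the lowest of the two numbers shown, while compound 3 gives 1.11 10^-6 cm/s; this gap lies within the usual scatter, so the two cannot be ordered. Compound 2 is reported only as "impermeable" (no number reported), with no number. Compound 4 `CCCC[C@H](NC(=O)[C@H](CCCCN)NC(=O)[C@H](CCCNC(=N)N)NC(=O)c1ccc(/C=C2\SC(=S)N(C3CCCC3)C2=O)cc1)C(N)=O` differs from compound 1 in one place: cyclopentyl in place of 1-(methoxycarbonyl)pentyl on an amide-type nitrogen in a ring. Among the measured compounds shown here, no measured pair shows this change, so there is no step to lean on. Both measured numbers sit low and the peptide part is unchanged. The expected step of a 1.0-fold higher number from compound 1 to compound 4 (0.01 log units; within the scatter) is therefore no more than the scatter. Compound 4 is estimated at 0.9 10^-6 cm/s, between 0.3 10^-6 cm/s and 2.5 10^-6 cm/s.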

Compound 4, apparent permeability: 2.31 10^-6 cm/s
Compound 4: the middle estimate sits 2.6-fold (0.41 log units) below what was measured; the measured number falls inside the stated range.
By their numbers in this assay, from the lowest: compounds 1 and 3 (each within the scatter of the next); then compound 4.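

Among the compounds shown here, this is the first step read at this position: in this assay, cyclopentyl in place of 1-(methoxycarbonyl)pentyl on the amide-type nitrogen in a ring gives a 2.7-fold higher number from compound 1 to compound 4 (0.42 log units; beyond the scatter). The group on this nitrogen can therefore shift the read-out beyond the scatter while the peptide part stays unchanged. No measurement shown accounts for the rise.

The ring arrives and the ester leaves in the same change, so the compounds shown do not tell which of the two goes with the rise. A plain pentyl chain or a carboxylic acid on this nitrogen would help pull them apart.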